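Compound 3 to compound 4: changing the amine nitrogen group

The source may hold more compounds than are shown below. What is called first, only, known or untested is meant among the compounds shown, and "the series" means these compounds.

The series shares one core, and cytotoxicity is the only read-out. In a functional assay on KB cells (Homo sapiens) for cytotoxicity, read by sulforhodamine B assay (on this read-out higher numbers stand for weaker inhibition and lower numbers for stronger inhibition), compound 1 `C=C1[C@@H](OC(C)=O)C[C@@H]2[C@](C)(CO[Si](C)(C)C(C)(C)C)[C@H](OC(C)=O)CC[C@@]2(C)[C@@H]1C[C@@H](Nc1ccc(OC)c(OC)c1)C1=CCOC1=O` gives 5800 nM and compound 2 `C=C1[C@@H](OC(C)=O)C[C@@H]2[C@](C)(COC=O)[C@H](OC(C)=O)CC[C@@]2(C)[C@@H]1C[C@@H](Nc1ccccc1F)C1=CCOC1=O` gives 29000 nM.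

Compound 3 `C=C1[C@@H](OC(C)=O)C[C@@H]2[C@](C)(COC=O)[C@H](OC(C)=O)CC[C@@]2(C)[C@@H]1C[C@@H](Nc1ccc(OC)c(OC)c1)C1=CCOC1=O` gives > 50000 nM, which is a limit of the assay and not a number. It therefore stands at the limit of > 50000 nM in this assay, at which 1 of the 3 values shown sits, and only a floor can be read for any step that ends on it.

Compound 4 `C=C1[C@@H](OC(C)=O)C[C@@H]2[C@](C)(COC=O)[C@H](OC(C)=O)CC[C@@]2(C)[C@@H]1C[C@@H](Nc1ccc(C(=O)O)cc1)C1=CCOC1=O` differs from compound 3 at one place: 4-carboxyphenyl in place of 3,4-dimethoxyphenyl on an amine nitrogen.

The closest measured change is an at least 1.7-fold higher number from compound 2 to compound 3 (0.23 log units; that floor lies within the scatter), also made on the amine nitrogen, and its floor gives no firm size for a change there. The larger change, an at least 8.6-fold higher number from compound 1 to compound 3 (0.93 log units; beyond the scatter), lies on an oxygen on a saturated carbon. Compound 4 keeps the group of compound 3 at that place, so this step argues for no return towards the value of compound 1.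

No step beyond the scatter is expected in this assay, in either direction. The expected change is a number no higher from compound 3 to compound 4 (the limit leaves the size open). A report at the assay limit is expected to be more likely than a number. The estimate for compound 4 is 50000 nM, with an expected range of 20000 nM to 100000 nM.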

Compound 4, half-maximal inhibitory concentration: > 50000 nM
Compound 4: no number, only a limit; the forecaster's own chance of this, stated with the estimate: 65%; the middle value sits exactly at the limit.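

In this assay compound 4 gives > 50000 nM, which is a limit of the assay and not a number. The step between compound 3 and compound 4 cannot be read, and the new result adds a second compound at that limit: the limit of > 50000 nM in this assay, at which 2 of the 4 values shown sit.

On the amine nitrogen, 4-carboxyphenyl in place of 2-fluorophenyl gives an at least 1.7-fold higher number from compound 2 to compound 4 (0.23 log units; that floor lies within the scatter), so this change also has no firm size. Of the three compounds that share the group of compound 3 on the oxygen, only compound 2 gives a number, 29000 nM, and 3,4-dimethoxyphenyl and 4-carboxyphenyl cannot be told apart in this assay.

On these data alone, whether 4-carboxyphenyl would give a readable number alongside the silicon-bearing group of compound 1 remains open, and that pairing would show how much of the gap at the oxygen carries over to a different group on the nitrogen. Also open, as far as these compounds go, is how an unsubstituted phenyl, an aryl group bearing an amine, or a longer chain on the amine nitrogen would read against 2-fluorophenyl on the shared core.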